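A few compounds are considered here, and "the series" means these few. Any claim that something is new, unique, unknown or untested is made for them only; others in the source may bear on it.

Going by the values given here, compound 1 `COC(=O)C1=C(C)NC(C)=C(C(=O)OC)C1c1c(-c2ccsc2)nc2sc(C)cn12` is the weaker of the two measured members. In a functional assay on ileum (Cavia porcellus) for inhibition (a lower number here means a stronger inhibitor, a higher number a weaker inhibitor), compound 1 gives 3520 nM, the highest number of the two measured; its nearest neighbour is compound 2 `CCOC(=O)C1=C(C)NC(C)=C(C(=O)OCC)C1c1c(-c2cc(OC)ccc2OC)nc2sccn12`, which in this assay gives 46 nM, a gap beyond the usual scatter. Among the compounds with values here, the two compounds differ at more than one place, so no single step between them can be set out; their two values alone show that compound 2 sits far lower.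

Compound 3 `COC(=O)C1=C(C)NC(C)=C(C(=O)OC)C1c1c(-c2ccsc2)nc2sccn12` differs from compound 1 at one place only: hydrogen in place of methyl on an aromatic carbon. The change removes the methyl from the fused ring of the core of compound 1 and leaves all other groups untouched. Nothing measured in the series speaks to this particular change; compound 2 differs at other positions as well and cannot be read as a guide. Within the data shown here, with no step in hand, the expectation is a step in this assay no larger than the scatter, with no firm direction. Compound 3 is accordingly expected at 3000 nM, within 1200 nM to 8000 nM. The estimated step of a 1.2-fold lower number from compound 1 to compound 3 (0.07 log units; within the scatter) is expected to remain within the scatter.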

Compound 3, half-maximal inhibitory concentration: 2.3 nM
Estimate against measurement, compound 3: 1300-fold (3.12 log units) above, outside the stated range (below it).
By their numbers in this assay, from the lowest: compound 3; then compound 2; then compound 1.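

In this assay, going by these compounds alone, the single change of hydrogen in place of methyl on an aromatic carbon gives a 1500-fold lower number from compound 1 to compound 3 (3.18 log units; beyond the scatter) and so marks this position, on the five-membered aromatic ring with 1 nitrogen and 1 sulfur, as one where removing one heavy atom is enough for a large step beyond the scatter. Before this pair, no step in the series isolated this position, and the gap between compound 1 and compound 2 could not be assigned to any one place. With all other groups of the core of compound 1 unchanged, the step now belongs to this methyl-to-hydrogen change alone, though nothing at hand accounts for its size.

Only methyl and hydrogen are shown at this carbon, so it remains open how groups such as ethyl, chlorine or hydroxymethyl would place a compound relative to these two. From the compounds shown here alone, it is also open whether a step of this size would recur with the ethyl esters and dimethoxyphenyl group of compound 2, which would need a methyl-bearing partner of compound 2 for comparison.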